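The compounds below may be only part of what the source reports. "The series", "measured", "known", "first", "only" and "open" are said of these compounds alone.

Measured compounds and their values:
compound 1 `CC(C)(C)Cc1csc(N)c1C(=O)c1ccc(Cl)cc1` — 1%
compound 2 `CC(C)(C)Cc1c(-c2ccoc2)sc(N)c1C(=O)c1ccc(Cl)cc1` — 1%
compound 3 `CC(C)(C)Cc1c(-c2ccc(F)cc2F)sc(N)c1C(=O)c1ccc(Cl)cc1` — 1%

All three were tested in an assay on CHO cells for displacement of a labelled ligand from adenosine receptor A1 (Homo sapiens), read by scintillation counting, tested at 10 uM; on this read-out higher numbers stand for more inhibition at the one concentration tested (going by the name of the read-out) and lower numbers for less inhibition. Compound 1 stands level with compounds 2 and 3 at the digits shown; its nearest neighbour is compound 2 and its furthest is compound 3, and in neither case does the difference rise out of the scatter. The steps of no change at the digits printed from compound 1 to compound 2 (within the scatter) and no change at the digits printed from compound 1 to compound 3 (within the scatter) both show that putting an aromatic ring onto the hydrogen-bearing carbon of the core of compound 1 left this assay unmoved, and the step of no change at the digits printed from compound 2 to compound 3 (within the scatter) shows the same between the two substituted compounds.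

Compound 4 `Cc1cccc(-c2sc(N)c(C(=O)c3ccc(Cl)cc3)c2CC(C)(C)C)c1` is not yet measured. Its change from compound 1 is 3-methylphenyl in place of hydrogen on an aromatic carbon, a third aromatic ring at the same position where the furan-3-yl and 2,4-difluorophenyl groups entered. Because no change at the digits printed from compound 1 to compound 2 (within the scatter) and no change at the digits printed from compound 1 to compound 3 (within the scatter) were both flat, the step of no change at the digits printed from compound 1 to compound 4 (within the scatter) is expected to be none beyond the scatter. Compound 4 is therefore estimated at 1%, within 0% to 10%.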

Compound 4, a percentage reported as inhibition, at one concentration (the size of the read-out at that concentration, not a potency): 1%
For compound 4 middle estimate and measured number coincide at the digits printed; the range from low to high includes it.
By their numbers in this assay, from the lowest: compounds 1, 2, 3 and 4 (each within the scatter of the next).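

In this assay a 3-methylphenyl group on the aromatic carbon next to the ring sulfur gives no change at the digits printed from compound 1 to compound 4 (within the scatter), which extends the flat result at this position to a carbon-only ring carrying a methyl group rather than fluorines. Among the ring-bearing compounds, the exchanges give no change at the digits printed from compound 3 to compound 4 (within the scatter) and no change at the digits printed from compound 2 to compound 4 (within the scatter), so all three rings tested here stand level in this assay. Nothing available gives a reason for this flatness.

As far as these compounds go, compound 1 itself gives only 1%, so it remains open whether any group at this position can raise the inhibition, for example a ring bearing an amine or a carboxylic acid, or a longer chain. From the compounds shown here alone, the neopentyl group and the (4-chlorophenyl)carbonyl group are the same in all four compounds, so what changing them would do also stays open.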